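From Fluoromethyl to Trifluoromethyl on the Shared Core

The compounds below may be only part of what the source reports. "The series", "measured", "known", "first", "only" and "open" are said of these compounds alone.

Of the compounds shown here, three have been measured in a functional assay on the whole organism (aorta) with Rattus norvegicus as the target; on this read-out lower numbers stand for smaller maximal responses and higher numbers for larger maximal responses. Compound 1 `C/N=C(/S)C1=CC(C)(C(F)(F)F)Oc2ccc([N+](=O)[O-])cc21` gives 62.5%. Compound 2 `CC1(C)C=C(C(=O)NCCC#N)c2cc([N+](=O)[O-])ccc2O1` gives 73.1%, and compound 3 `CC1(CF)C=C(C(=O)NCCC#N)c2cc([N+](=O)[O-])ccc2O1` gives 71%. On these three numbers compound 3 stands second highest: its nearest neighbour is compound 2 and its furthest is compound 1, and both gaps lie within the usual scatter, so the three cannot be told apart with confidence.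

Compound 4 `CC1(C(F)(F)F)C=C(C(=O)NCCC#N)c2cc([N+](=O)[O-])ccc2O1` has not yet been measured. It differs from compound 3 in one place: trifluoromethyl in place of fluoromethyl on a saturated ring carbon.

Among the measured compounds shown here, only one measured step speaks to this kind of change. It runs a number 2.1 percentage points lower from compound 2 to compound 3 (within the scatter), where a fluoro took the place of a hydrogen on a saturated chain carbon, and it stayed within the scatter. For the measured compounds named here, compound 1 also carries a trifluoromethyl on a saturated ring carbon, but the rest of its structure differs from compound 4, so its value shows only that such a compound can reach the measured range. In this assay the change is therefore expected to produce a step no larger than the scatter, a number 2 percentage points lower from compound 3 to compound 4 (within the scatter). Compound 4 is expected to give 69%, with the likely range from 58% to 80%.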

Compound 4, intrinsic activity: the largest response reached, in percent of the reference agonist's: 70.6%
Compound 4: middle estimate off by 1.6 percentage points, on the low side; the range from low to high includes it.
By their numbers in this assay, from the lowest: compounds 1, 4, 3 and 2 (each within the scatter of the next, the first and the last beyond it).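

In this assay, among the compounds shown here, trifluoromethyl in place of fluoromethyl on this saturated ring carbon gives a number 0.4 percentage points lower from compound 3 to compound 4 (within the scatter), and trifluoromethyl in place of methyl gives a number 2.5 percentage points lower from compound 2 to compound 4 (within the scatter), so the maximal response does not separate these three groups at this position, even though the earlier compounds had compared only methyl and fluoromethyl there. Compound 4 also pairs with compound 1, which carries the same trifluoromethyl and differs only on the double-bonded ring carbon: the (2-cyanoethyl)carbamoyl group in place of the group of 4 heavy atoms gives a number 8.1 percentage points higher from compound 1 to compound 4 (within the scatter), so this change of group cannot be told apart from the usual scatter either. No measurement shown here explains why these numbers lie so close together.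

The compounds shown leave open whether a larger or different group on the saturated ring carbon, such as a hydroxymethyl, an aminomethyl or a longer chain, would stay in the same range. They also leave open what a carboxylic acid or an amine would do in place of the (2-cyanoethyl)carbamoyl group.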